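Swapping dimethylamino for hydroxy on a weakly active scaffold

A few compounds are considered here, and "the series" means these few. Any claim that something is new, unique, unknown or untested is made for them only; others in the source may bear on it.

Of the compounds shown here, three built on the same core have been tested in a functional assay on cells (Mus musculus) for antiproliferative activity, read by sulforhodamine B assay, with a stated time of 5 days; on this read-out lower numbers stand for stronger inhibition and higher numbers for weaker inhibition. Compound 1, `C#CCOc1ccc(C(C)(C)C)cc1C1(c2ccccc2)C(=O)Nc2ccccc21`, gives only a limit of the assay, > 20000 nM, so no number is known for it. Compound 2, `CN(C)c1ccc(C2(c3cc(C(C)(C)C)ccc3O)C(=O)Nc3ccccc32)cc1`, gives 10900 nM in this assay. Compound 3, `COc1ccc(C2(c3cc(C(C)(C)C)ccc3O)C(=O)Nc3ccc(OC)cc32)cc1`, gives 14300 nM in this assay. Among the two actual numbers, compound 2 carries the lower one, but its gap to compound 3 lies within the usual scatter of repeated measurements, so the two cannot be told apart. Both sit at the weak end of the range.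

Compound 4, `CC(C)(C)c1ccc(O)c(C2(c3ccc(O)cc3)C(=O)Nc3ccccc32)c1`, has not yet been measured. It differs from compound 2 in one place: hydroxy in place of dimethylamino on an aromatic carbon. For the measured compounds named here, no pair of measured compounds here isolates this change, so there is nothing to lean on for its direction. Given how close compound 2 and compound 3 sit, the expectation for compound 4 is a step that stays within the scatter, with no clear gain or loss. Compound 4 is therefore expected to give about 13000 nM in this assay, somewhere between 5000 nM and 40000 nM, which amounts to an expected step of a 1.2-fold higher number from compound 2 to compound 4 (0.08 log units; within the scatter).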

Compound 4, half-maximal inhibitory concentration: 17300 nM
Compound 4: middle estimate off by 1.3-fold (0.12 log units), on the low side, and the stated range covers the measured number.
By their numbers in this assay, from the lowest: compounds 2, 3 and 4 (each within the scatter of the next). At a limit, above all of these: compound 1.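

In this assay, replacing 4-(dimethylamino)phenyl with 4-hydroxyphenyl gives a 1.6-fold higher number from compound 2 to compound 4 (0.20 log units; within the scatter), so the change in this group cannot be told apart from repeat-measurement scatter. For the compounds shown here, this is the first direct reading of a single change on the shared core, as the earlier compounds differ from one another in more than one place, and it shows that a dimethylamino group and a hydroxy group at this position leave the activity at the same weak level. Compound 1 gives no number, only a limit of the assay, and this limit marks how little of the measurable range lies beyond the weak values seen here: the limit of > 20000 nM in this assay, at which 1 of the 4 values shown sits.

From the compounds shown here alone, whether any group on this aromatic ring can move the number clearly away from the weak end remains open, for instance a primary amine, a carboxylic acid or a fluorine atom in the same place. Going by these compounds, a single step also cannot show a trend, so it remains unknown whether this position matters for activity on this core at all.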